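The source may report more compounds than this note shows. Statements on the series, on what has been measured and on what is new or still open speak of the compounds shown alone.

Measured so far in a functional assay on Molt4/C8 cells (Homo sapiens) for cytotoxicity; a higher number here means a weaker inhibitor, a lower number a stronger inhibitor:
compound 1, `Cc1cccc(C)c1NC(=O)/C=C/C(=O)N1C/C(=C\c2ccc([N+](=O)[O-])cc2)C(=O)/C(=C/c2ccc([N+](=O)[O-])cc2)C1`: 210 nM
compound 2, `COc1ccc(NC(=O)/C=C/C(=O)N2C/C(=C\c3ccc([N+](=O)[O-])cc3)C(=O)/C(=C/c3ccc([N+](=O)[O-])cc3)C2)cc1`: 940 nM
compound 3, `CC(=O)c1ccc(NC(=O)/C=C/C(=O)N2C/C(=C\c3ccc([N+](=O)[O-])cc3)C(=O)/C(=C/c3ccc([N+](=O)[O-])cc3)C2)cc1`: 390 nM

On these numbers compound 3 stands second highest of the three. Its nearest neighbour is compound 1, and a 1.9-fold higher number from compound 1 to compound 3 (0.27 log units; within the scatter) lies within the scatter; its furthest is compound 2, and a 2.4-fold lower number from compound 2 to compound 3 (0.38 log units; beyond the scatter) is beyond the scatter but modest. The three share one core and differ only in the aryl group on the amide-type nitrogen; a 4.5-fold higher number from compound 1 to compound 2 (0.65 log units; beyond the scatter) is the widest swing in the set, and even that is modest.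

Compound 4, `O=C(/C=C/C(=O)N1C/C(=C\c2ccc([N+](=O)[O-])cc2)C(=O)/C(=C/c2ccc([N+](=O)[O-])cc2)C1)Nc1ccc(Cl)cc1`, is the next step from compound 3: chloro in place of acetyl on an aromatic carbon. For the measured compounds named here, no measured compound carries chloro, so nothing bears on the new group directly. What does bear on the step is the record of swaps at the same place: a 2.4-fold lower number from compound 2 to compound 3 (0.38 log units; beyond the scatter) and a 1.9-fold higher number from compound 1 to compound 3 (0.27 log units; within the scatter) are both small, so exchanging the group on that aromatic carbon has so far moved the numbers little. The expected step is therefore a 1.0-fold higher number from compound 3 to compound 4 (0.01 log units; within the scatter), within or just beyond the scatter, with no firm direction. Compound 4 is estimated at 400 nM, with a range of 180 nM to 900 nM.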

Compound 4, half-maximal inhibitory concentration: 1200 nM
Compound 4: the middle estimate sits 3.0-fold (0.48 log units) below what was measured; measured number outside the range, above it.
By their numbers in this assay, from the lowest: compounds 1 and 3 (each within the scatter of the next); then compounds 2 and 4 (each within the scatter of the next).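

In this assay, the aromatic carbon para to a large group is more sensitive to exchange than the earlier swaps suggested: a 3.1-fold higher number from compound 3 to compound 4 (0.49 log units; beyond the scatter), so chloro and acetyl are distinguishable here, whereas a 1.3-fold higher number from compound 2 to compound 4 (0.11 log units; within the scatter) leaves chloro and methoxy indistinguishable. Among the three compounds with a single group at this carbon, acetyl therefore stands apart, with compound 3 on the lower side, while compounds 2 and 4 read alike. For the compounds shown here, the change from 2,6-dimethylphenyl gives the widest step so far, a 5.7-fold higher number from compound 1 to compound 4 (0.76 log units; beyond the scatter), but compound 3 remains within the scatter of compound 1, so 2,6-dimethylphenyl does not separate from every group at the amide-type nitrogen, and no measurement available here accounts for the difference between acetyl and chloro.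

Going by these compounds, it remains open whether the lower number belongs to acetyl alone or extends to other carbonyl-bearing groups, such as an ester or a carboxylic acid, and how an amine on the same carbon would read. Also open, on these data alone, is whether chloro or acetyl added to the 2,6-dimethylphenyl ring of compound 1 would shift its number in the same way.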